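The source may hold more compounds than are shown below. What is called first, only, known or untested is meant among the compounds shown, and "the series" means these compounds.

The study compares three sulfanyl-bridged analogues on a shared core in a functional assay on MDA-MB-231 cells (Homo sapiens) for inhibition, read by MTT assay, with a stated time of 48 h; on this read-out higher numbers stand for weaker inhibition and lower numbers for stronger inhibition. Compound 1 `Cc1ccc(-c2nc3ccccn3c2Sc2ccccc2)cc1` gives > 100000 nM, which is a limit of the assay and not a number. Compound 2 `Cc1ccc(-c2nc3ccc(C)cn3c2Sc2ccccc2)cc1` gives 38000 nM in this assay. Compound 3 `Cc1ccc2nc(-c3ccc(Cl)cc3)c(Sc3ccccc3)n2c1` gives 94500 nM in this assay, the higher of the two numbers recorded. With chloro in place of methyl on an aromatic carbon the number rises: a 2.5-fold higher number from compound 2 to compound 3 (0.40 log units; beyond the scatter). With hydrogen in place of methyl on an aromatic carbon the number rises again: an at least 2.6-fold higher number from compound 2 to compound 1 (0.42 log units; beyond the scatter), read against (the limit of > 100000 nM in this assay, at which 1 of the 3 values shown sits).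

Compound 4 `Clc1ccc(-c2nc3ccccn3c2Sc2ccccc2)cc1` has not yet been measured. Within the data shown here, it differs from compound 3 by hydrogen in place of methyl on an aromatic carbon, the same change as the one from compound 2 to compound 1, which reads (hydrogen in place of methyl on an aromatic carbon), made at the same place. The two cores differ by chloro in place of methyl on an aromatic carbon.

Compound 4 is expected to give 220000 nM in this assay, with a range estimated from 90000 nM to 600000 nM. The expected step is a 2.3-fold higher number from compound 3 to compound 4 (0.37 log units; beyond the scatter), an estimate that rests on the measured step of an at least 2.6-fold higher number from compound 2 to compound 1 (0.42 log units; beyond the scatter) applied to a starting point already close to the limit of the assay. Because the limit of > 100000 nM in this assay, at which 1 of the 3 values shown sits, sits where it does, compound 4 is expected most likely to be reported as a limit rather than as a number.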

Compound 4, half-maximal inhibitory concentration: 24500 nM
Compound 4: the middle estimate sits 9.0-fold (0.95 log units) above what was measured; the whole stated range lies above it.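

In this assay, hydrogen in place of methyl on an aromatic carbon gives a 3.9-fold lower number from compound 3 to compound 4 (0.59 log units; beyond the scatter), so the change that raised the number on the core of compound 2 lowers it on the core of compound 3: the same change on two cores in this assay, an at least 2.6-fold higher number (0.42 log units; beyond the scatter) from compound 2 to compound 1 and a 3.9-fold lower number (0.59 log units; beyond the scatter) from compound 3 to compound 4, at least 10-fold (1.00 log units) apart, beyond the scatter of two such steps

Chloro in place of methyl on an aromatic carbon gives an at least 4.0-fold lower number from compound 1 to compound 4 (0.61 log units; beyond the scatter), so this change also reverses direction, here between the core of compound 2 and the core of compound 1: the same change on two cores in this assay, a 2.5-fold higher number (0.40 log units; beyond the scatter) from compound 2 to compound 3 and an at least 4.0-fold lower number (0.61 log units; beyond the scatter) from compound 1 to compound 4, at least 10-fold (1.00 log units) apart, beyond the scatter of two such steps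

This shows that neither change can be carried from one core to the other in this series as a fixed step, or even with a fixed direction, but it rests on only four compounds, does not show the cause of the reversal, and gives the gaps only as bounds, as the value of compound 1 is a limit of the assay and not a number: the limit of > 100000 nM in this assay, at which 1 of the 4 values shown sits.

The compounds shown leave open whether the same reversal would appear with other groups in these two spots, such as a fluoro group, a methoxy group or an amine. They also leave open how the picture would change if the phenyl ring on the sulfur carried a substituent, or if an oxygen or a methylene took the place of the sulfur bridge.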